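This account rests on a few compounds, and the source may have more. Where it says the series, first, only, none or still open, it means among the compounds named here.

Compound 1 `CO/C(O)=C1\C(C)=NC(C)=C(C(=O)OCCCN2C(=O)c3ccccc3S2(=O)=O)C1c1cccc(Cl)c1Cl`: 0.8 nM
Compound 2 `CC1=NC(C)=C(C(=O)OCCCN2C(=O)c3ccccc3S2(=O)=O)C(c2cccc(Cl)c2Cl)/C1=C(\O)OC(C)C`: 2.1 nM
Compound 3 `CC1=NC(C)=C(C(=O)OCCCN2C(=O)c3ccccc3S2(=O)=O)C(c2cccc(Cl)c2Cl)/C1=C(\O)OC(C)(C)C`: 3.1 nM

These numbers come from a functional assay (aorta) with Oryctolagus cuniculus as the target; a higher number here means a weaker inhibitor, a lower number a stronger inhibitor. Compound 2 cannot be told apart from its nearest neighbour: a 1.5-fold higher number from compound 2 to compound 3 (0.17 log units; within the scatter). Its furthest neighbour is clearly separate: a 2.6-fold higher number from compound 1 to compound 2 (0.42 log units; beyond the scatter).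

Compound 4 `CC1=NC(C)=C(C(=O)OCCCN2C(=O)c3ccccc3S2(=O)=O)C(c2ccccc2Cl)/C1=C(\O)OC(C)C` differs from compound 2 by having hydrogen in place of chloro on an aromatic carbon, turning 2,3-dichlorophenyl into 2-chlorophenyl (hydrogen in place of chloro on an aromatic carbon). Among the measured compounds shown here, no measured step touches this place. All three change the group on the oxygen, and the largest, a 3.9-fold higher number from compound 1 to compound 3 (0.59 log units; beyond the scatter), is modest. They give only a rough sense of size and no direction, so just a small change is expected: a 1.4-fold higher number from compound 2 to compound 4 (0.15 log units; within the scatter). Compound 4 is estimated at 3 nM, with an expected range of 1 nM to 10 nM.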

Compound 4, half-maximal inhibitory concentration: 1.3 nM
Compound 4: the middle estimate sits 2.3-fold (0.36 log units) above what was measured, within the range that was stated.
By their numbers in this assay, from the lowest: compounds 1, 4, 2 and 3 (each within the scatter of the next, the first and the last beyond it).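

Hydrogen in place of chloro on this aromatic carbon, turning 2,3-dichlorophenyl into 2-chlorophenyl, gives a 1.6-fold lower number from compound 2 to compound 4 (0.21 log units; within the scatter) in this assay. Among the compounds shown here, this is the first look at the aromatic ring rather than the group on the oxygen, and here compound 2 and compound 4 cannot be told apart, so this chloro is not needed for a low number in this pair. No available measurement offers a reason for this.

On these data alone, whether an amine or a methoxy group at this place would fit equally well stays open. So does whether this change behaves the same with methyl or tert-butyl on the oxygen.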